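A few compounds are considered here, and "the series" means these few. Any claim that something is new, unique, unknown or untested is made for them only; others in the source may bear on it.

Compounds measured so far:
- compound 1 `CN(c1cnccc1SCCCCC(=O)O)c1ccc(C#N)c2ccccc12`: 3580 nM
- compound 2 `CN(c1cnccc1SC(C)(C)C(=O)O)c1ccc(C#N)c2ccccc12`: 5360 nM

Compound 2 gives the higher of the two numbers in an assay on HEK293 cells for inhibition of solute carrier family 22 member 12 (Homo sapiens), read by scintillation counting, with stated times of 30 min and 15 min (a higher number here means a weaker inhibitor, a lower number a stronger inhibitor), though its distance from compound 1 is only a 1.5-fold higher number from compound 1 to compound 2 (0.18 log units; within the scatter), a gap within the scatter. Compound 3 `CN(c1cnccc1SCCCCCCC(=O)O)c1ccc(C#N)c2ccccc12` has not yet been measured. It differs from compound 2 by 6-carboxyhexyl in place of 1-carboxy-1-methylethyl on a sulfur. Among the measured compounds shown here, the only measured step that bears on this, from compound 1 to compound 2, changed the chain on the sulfur and stayed within the scatter. A similar outcome is expected here, so compound 3 is estimated at 3500 nM (range 1200 nM to 10000 nM), a step of a 1.5-fold lower number from compound 2 to compound 3 (0.19 log units; within the scatter).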

Compound 3, half-maximal inhibitory concentration: 4640 nM
Beside the measured number, compound 3's estimate is 1.3-fold (0.12 log units) below it; the range from low to high includes it.
By their numbers in this assay, from the lowest: compounds 1, 3 and 2 (each within the scatter of the next).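

In this assay the change to 6-carboxyhexyl gives a 1.2-fold lower number from compound 2 to compound 3 (0.06 log units; within the scatter) and the longer chain gives a 1.3-fold higher number from compound 1 to compound 3 (0.11 log units; within the scatter) so both new steps stay within the scatter. Across 1-carboxy-1-methylethyl, 4-carboxybutyl and 6-carboxyhexyl on this sulfur, neither added chain length nor the change of chain shape yet gives a readable difference. Nothing measured here says why the numbers stay so close.

Still open, as far as these compounds go, is whether a shorter chain such as carboxymethyl would shift the number beyond the scatter. Also open, from the compounds shown here alone, is what an amide or an amine would do in place of the carboxylic acid at the chain end.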